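This account rests on a few compounds, and the source may have more. Where it says the series, first, only, none or still open, it means among the compounds named here.

In an ADME assay on MT4 cells (Homo sapiens) for cytotoxicity, read by MTT assay (on this read-out higher numbers stand for lower toxicity in this test and lower numbers for higher toxicity in this test), three compounds sharing one core have been measured. Compound 1 `O=C(Nc1ccccc1)C1C(=O)N(O)C(=O)c2ccccc21` gives 106000 nM, compound 2 `O=C(Nc1cccc(F)c1)C1C(=O)N(O)C(=O)c2ccccc21` gives 64000 nM, and compound 3 `O=C(NCc1ccccc1)C1C(=O)N(O)C(=O)c2ccccc21` gives 130000 nM. Two steps fix where the benzyl amide stands in this small set. There is a 1.2-fold higher number from compound 1 to compound 3 (0.09 log units; within the scatter), and there is a 2.0-fold higher number from compound 2 to compound 3 (0.31 log units; beyond the scatter). It is thus level with the phenyl amide and modestly separated from the 3-fluorophenyl amide.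

The next structure is compound 4 `COc1ccc(CNC(=O)C2C(=O)N(O)C(=O)c3ccccc32)cc1`, and its difference from compound 3 is this: methoxy in place of hydrogen on an aromatic carbon. Put in words, it is methoxy in place of hydrogen on an aromatic carbon, so that phenyl becomes 4-methoxyphenyl.

Among the compounds with values here, no measured step carries a methoxy group, so the evidence is indirect. The only measured replacement of hydrogen on an aromatic carbon is fluoro, which gave a 1.7-fold lower number from compound 1 to compound 2 (0.22 log units; within the scatter). That step is small and points to a lower number, and a single step of this kind supports only a loose expectation in this assay. The expected change is therefore small and slightly downward, at most around the scatter: a 1.4-fold lower number from compound 3 to compound 4 (0.14 log units; within the scatter). Compound 4 is estimated at 95000 nM, with an expected range of 50000 nM to 170000 nM.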

Compound 4, half-maximal cytotoxic concentration: 119000 nM
Compound 4: middle estimate off by 1.3-fold (0.10 log units), on the low side; low and high end bracket the measured number.
By their numbers in this assay, from the lowest: compounds 2, 1, 4 and 3 (each within the scatter of the next, the first and the last beyond it).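

Within the data shown here, the methoxy step is the first replacement of hydrogen on an aromatic carbon in the benzyl amide series, at a place para to a large group, and in this assay it gives a 1.1-fold lower number from compound 3 to compound 4 (0.04 log units; within the scatter), so this change leaves no readable mark on the number. Together with a 1.7-fold lower number from compound 1 to compound 2 (0.22 log units; within the scatter), also within the scatter, it means that neither of the two replacements of hydrogen on an aromatic carbon shown here moves the read-out readably, although they differ in the group that enters and in the amide that carries it. No measurement offered here accounts for why the number holds when methoxy enters, so this result stands as an observation without an explanation.

The compounds shown leave open whether the same place on the ring would stay as quiet with a group of another kind, such as an amine, a carboxylic acid or a hydroxyl group, or with a longer chain in place of methoxy. They also leave open whether lengthening the link between the amide nitrogen and the ring to a two-carbon chain would change the number in this assay in a way that lies beyond the scatter.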